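Bromo in Place of Isopropyl on a Weakly Binding Core

This account rests on a few compounds, and the source may have more. Where it says the series, first, only, none or still open, it means among the compounds named here.

Three compounds of this series have been examined in an assay on isolated protein for binding affinity to retinoic acid receptor alpha (Homo sapiens); a higher number here means weaker binding, a lower number tighter binding. Compound 1 `CCCc1cc2c(cc1C(=O)c1ccc(C(=O)O)cc1)C(C)(C)CCC2(C)C` gives in this assay > 1000 nM, which is a limit of the assay and not a number. Compound 2 `CC1(C)CCC(C)(C)c2cc(C(=O)c3ccc(C(=O)O)cc3)c(F)cc21` gives in this assay > 1000 nM, again only a limit. Fluoro in place of propyl on an aromatic carbon therefore gives a step that the two limits leave unreadable from compound 1 to compound 2. Compound 3 `C=C(c1ccc(C(=O)O)cc1)c1cc2c(cc1C(C)C)C(C)(C)CCC2(C)C` gives in this assay > 1000 nM, also a limit. Its standing cannot be read against the others, since all three values sit at the same limit (the limit of > 1000 nM in this assay, at which 3 of the 3 values shown sit).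

Compound 4 `C=C(c1ccc(C(=O)O)cc1)c1cc2c(cc1Br)C(C)(C)CCC2(C)C` differs from compound 3 by bromo in place of isopropyl on an aromatic carbon, a bromo in place of isopropyl on an aromatic carbon. Going by the values given here, the only measured step, from compound 1 to compound 2, is unreadable, so no size can be carried over to this change. The most that can be expected is that compound 4 stays near the limit, with a step that the limit leaves unreadable from compound 3 to compound 4 estimated as no step beyond the scatter. Compound 4 is therefore expected in this assay at 1500 nM, in a range from 300 nM to 8000 nM.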

Compound 4, dissociation constant: > 1000 nM
Compound 4 was reported as a limit (the forecaster's own chance of this, stated with the estimate: 70%); the middle value is on the limit's open side.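

Compound 3 and compound 4 both stand only as limits in this assay, so no step can be read between them for bromo in place of isopropyl: the limit of > 1000 nM in this assay, at which 4 of the 4 values shown sit. The compounds shown leave open which change to the shared core, if any, gives binding that can be read as a number.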